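The compounds below may be only part of what the source reports. "The series", "measured", "known", "first", "only" and "open" are said of these compounds alone.

In a physicochemical assay for solubility, in phosphate buffer, at pH 7.4 (on this read-out higher numbers stand for higher solubility and lower numbers for lower solubility), compound 2 `O=C1/C(=C/c2cccc(C(F)(F)F)c2)CCC/C1=C\c1cccc(C(F)(F)F)c1` gives < 1000 nM, which is a limit of the assay rather than a number. Compound 1 `N#CC1(c2ccccc2)C/C(=C\c2cccc(F)c2)C(=O)/C(=C/c2cccc(F)c2)C1` likewise reaches only a limit, giving < 1000 nM in this assay. Both results therefore rest at the limit of < 1000 nM in this assay, at which 2 of the 2 values shown sit. Compound 3 `O=C1/C(=C/c2cccc(C(F)(F)F)c2)CC(c2ccccc2)C/C1=C\c1cccc(C(F)(F)F)c1` differs from compound 2 by phenyl in place of hydrogen on a saturated ring carbon. Among the measured compounds shown here, no measured step of this kind is available, so the direction remains uncertain, but with a limit already reached the expected step is a step that the limit leaves unreadable from compound 2 to compound 3, most likely leaving the value at the limit again. For compound 3 the estimate in this assay is 300 nM, within 50 nM to 1000 nM.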

Compound 3, solubility: 1100 nM
Estimate against measurement, compound 3: 3.7-fold (0.56 log units) below; measured number above the stated range.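

In this assay, phenyl in place of hydrogen on a saturated ring carbon gives an at least 1.1-fold higher number from compound 2 to compound 3 (0.04 log units; that floor lies within the scatter). Only the floor of this step is known, so it does not establish a real rise. Still, this position carries a phenyl while compound 3 gives a true number rather than a limit, which neither earlier compound did.

Going by these compounds, the true size of the step stays open: the limit of < 1000 nM in this assay, at which 2 of the 3 values shown sit. Also open, on these data alone, is how the read-out would respond to an amine or a carboxylic acid in place of that phenyl.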